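The source may report more compounds than this note shows. Statements on the series, on what has been measured and on what is new or still open speak of the compounds shown alone.

Compound 3 `CC#C[C@@H](Cc1nnn[nH]1)c1ccc(OCc2ccc3sc(F)c(-c4ccc(OCCOC)cc4C)c3c2)cc1` gives 24 nM in a functional assay on cells for agonist activity at Free fatty acid receptor 1 (Rattus norvegicus), read by FLIPR and calcium flux (a higher number here means that more compound is needed for the effect, a lower number that less compound is needed), the second highest of the three numbers. Compound 1 `CC#C[C@@H](Cc1nnn[nH]1)c1ccc(OCc2ccc3sc(C)c(-c4ccc(OCCOC)cc4C)c3c2)cc1` gives 32 nM in this assay, and compound 2 `CC#C[C@@H](Cc1nnn[nH]1)c1ccc(OCc2ccc3scc(-c4ccc(OCCOC)cc4C)c3c2)cc1` gives 4 nM. Compound 4 `CC#C[C@@H](Cc1nnn[nH]1)c1ccc(OCc2ccc3sc(C(F)(F)F)c(-c4ccc(OCCOC)cc4C)c3c2)cc1` differs from compound 3 by trifluoromethyl in place of fluoro on an aromatic carbon. The steps at this carbon show that the smallest group gives the lowest number: an 8.0-fold lower number from compound 1 to compound 2 (0.90 log units; beyond the scatter) and a 6.0-fold higher number from compound 2 to compound 3 (0.78 log units; beyond the scatter), while a 1.3-fold lower number from compound 1 to compound 3 (0.12 log units; within the scatter). Among the compounds with values here, since fluoro and methyl sit close together and both well behind hydrogen, a still larger trifluoromethyl group is expected to move the number in compound 4 upward only modestly, a 2.1-fold higher number from compound 3 to compound 4 (0.32 log units; beyond the scatter), though no measured step tests a group of this size. Compound 4 is therefore estimated at 50 nM, with a range of 15 nM to 160 nM.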

Compound 4, half-maximal effective concentration: 14 nM
Compound 4: the middle estimate sits 3.6-fold (0.55 log units) above what was measured, and the stated range ends above it.
By their numbers in this assay, from the lowest: compound 2; then compounds 4, 3 and 1 (each within the scatter of the next, the first and the last beyond it).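

Trifluoromethyl and fluoro cannot be told apart at this carbon, with a 1.7-fold lower number from compound 3 to compound 4 (0.23 log units; within the scatter) as the step between them. Size alone therefore does not order the groups here: trifluoromethyl stands clear of methyl, with a 2.3-fold lower number from compound 1 to compound 4 (0.36 log units; beyond the scatter) in its favour, yet hydrogen stays ahead, with a 3.5-fold higher number from compound 2 to compound 4 (0.54 log units; beyond the scatter) marking the remaining gap. Nothing given here accounts for this order.

The compounds shown leave open whether chloro, methoxy or a nitrile at this carbon would come nearer to hydrogen. They also leave open how an amine would behave here.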